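The source may report more compounds than this note shows. Statements on the series, on what has been measured and on what is new or still open speak of the compounds shown alone.

Compound 2 `O=C(Nc1cccc(-c2oc3cc(-c4ccc(F)cc4)ccc3c(=O)c2O)c1)c1cccc(F)c1` gives the lowest number of the two measured in a functional assay on MDA-MB-231 cells (Homo sapiens) for antiproliferative activity, read by CCK-8 assay, with a stated time of 72 h (a higher number here means a weaker inhibitor, a lower number a stronger inhibitor), at 2510 nM; compound 1 `O=C(Nc1cccc(-c2oc3cc(-c4ccc(F)cc4)ccc3c(=O)c2O)c1)c1ccc(F)cc1` gives 16000 nM in this assay. Compound 3 `CCc1ccc(C(=O)Nc2cccc(-c3oc4cc(-c5ccc(F)cc5)ccc4c(=O)c3O)c2)cc1` differs from compound 2 by 4-ethylphenyl in place of 3-fluorophenyl on a carbonyl carbon. Within the data shown here, the only step seen on this carbonyl, a 6.4-fold lower number from compound 1 to compound 2 (0.80 log units; beyond the scatter), concerns the fluorine position alone, so it bears on the change only loosely. A return to a para-substituted ring is expected to cost some potency, giving an estimated 2.0-fold higher number from compound 2 to compound 3 (0.30 log units; within the scatter). Compound 3 is therefore estimated at 5000 nM, within a range of 1500 nM to 16000 nM.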

Compound 3, half-maximal inhibitory concentration: 9070 nM
Beside the measured number, compound 3's estimate is 1.8-fold (0.26 log units) below it; low and high end bracket the measured number.
By their numbers in this assay, from the lowest: compound 2; then compounds 3 and 1 (each within the scatter of the next).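

In this assay, 4-ethylphenyl in place of 3-fluorophenyl on this carbonyl gives a 3.6-fold higher number from compound 2 to compound 3 (0.56 log units; beyond the scatter) and so shows that a different substituent on the ring, not only a moved fluorine, can shift the number. Ethyl in place of fluoro on the aromatic carbon gives a 1.8-fold lower number from compound 1 to compound 3 (0.25 log units; within the scatter) and so does not separate these two groups. Nothing given here explains either step. On these data alone, whether an amine or a carboxylic acid in place of the ethyl or the fluoro would shift the number stays open, as does the result for a plain phenyl on this carbonyl.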